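A Nitrile in Place of a Methyl at a Chain End

A few compounds are considered here, and "the series" means these few. Any claim that something is new, unique, unknown or untested is made for them only; others in the source may bear on it.

Compound 1, `CCCCCc1nc(O)cc(O)n1`, carries a five-carbon chain on the shared core. In a functional assay on HEK293 cells for agonist activity at G-protein coupled receptor 84 (Homo sapiens), read by calcium flux (a higher number here means a larger maximal response, a lower number a smaller maximal response), compound 1 gives 84.9%. Among the measured compounds shown here, this is the lower of the two numbers measured so far; the other compound, compound 2, `CCc1ccc(CCc2nc(O)cc(O)n2)cc1`, gives 97.4% in this assay, a number higher than that of compound 1 by a gap that lies beyond the usual scatter.

Compound 3, `N#CCCCCc1nc(O)cc(O)n1`, has not yet been measured. It differs from compound 1 in one place: cyano in place of methyl on a saturated chain carbon, four bonds along the chain from an aromatic carbon. For the measured compounds named here, no measured pair shows this kind of change, so no step can be carried over from the data. A modest fall in the largest response seems more likely than a rise, although a result within the scatter cannot be excluded. Compound 3 is expected to give 72% in this assay, with an estimated range from 45% to 98%. The expected step of a number 12.9 percentage points lower from compound 1 to compound 3 (beyond the scatter) is a small one downward.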

Compound 3, largest response reached (reported as percent of maximum), in percent of the reference or control that the assay uses: 55.2%
The estimate for compound 3 lay 16.8 percentage points above the measured number, and the stated range covers the measured number.
By their numbers in this assay, from the lowest: compound 3; then compound 1; then compound 2.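

In this assay, cyano in place of methyl gives a number 29.7 percentage points lower from compound 1 to compound 3 (beyond the scatter). Among the compounds shown here, this is the first measured step between two compounds that differ in one place, and it shows that the largest response is sensitive to a change on a saturated chain carbon, four bonds along the chain from an aromatic carbon. Nothing available on these compounds explains the fall in response.

This single step cannot separate the loss of the methyl from the arrival of the nitrile, so it gives no general rule for groups at this position. Going by these compounds, it remains open whether a hydroxyl, an amine or a carboxylic acid in the same place would also lower the response, and whether a nitrile on a longer chain would do the same.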